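A few compounds are considered here, and "the series" means these few. Any claim that something is new, unique, unknown or untested is made for them only; others in the source may bear on it.

Values in an ADME assay on L6 cells (Rattus norvegicus) for cytotoxicity, read by microscopy and resazurin assay, with a stated time of 72 h; on this read-out higher numbers stand for an effect only at larger amounts of compound and lower numbers for an effect already at smaller amounts:
Compound 1 `Cc1cc(/C=C2\S/C(=N\c3ccccc3)N(C3CCCCC3)C2=O)c(C)n1-c1ccccc1`: > 200000 nM, a limit
Compound 2 `Cc1cc(/C=C2\S/C(=N\c3ccccc3)N(C3CCCCC3)C2=O)c(C)n1-c1cccc(C(F)(F)F)c1`: > 170000 nM, a limit
Compound 3 `O=C1/C(=C/c2ccn(Cc3ccccc3)c2)S/C(=N\c2ccccc2)N1C1CCCCC1`: > 200000 nM, a limit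

Compound 2 has no exact number in this assay, standing only at the limit of > 170000 nM in this assay, at which 1 of the 3 values shown sits. The other two compounds stand at the limit of > 200000 nM in this assay, at which 2 of the 3 values shown sit, so no value shown here is an exact number.

In compound 4 `Cc1cc(/C=C2\S/C(=N\c3ccccc3)N(C3CCCCC3)C2=O)c(C)n1C`, methyl takes the place of 3-(trifluoromethyl)phenyl on an aromatic nitrogen (methyl in place of 3-(trifluoromethyl)phenyl on an aromatic nitrogen). For the measured compounds named here, the one measured step that bears on this change concerns the same substituent, where trifluoromethyl replaces hydrogen on an aromatic carbon. That step is a step that the two limits leave unreadable from compound 1 to compound 2, so it offers no size to carry over. With nothing readable to suggest a direction, no step beyond the usual scatter is expected in this assay, and compound 4 may well be reported as a limit too. The expected change is a step that the limit leaves unreadable from compound 2 to compound 4. For compound 4 the estimated value is 180000 nM, with an expected range from 70000 nM to 250000 nM.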

Compound 4, half-maximal effective concentration: > 230000 nM
Compound 4 ended at the assay's limit; the forecaster's own chance of this, stated with the estimate: 65%; middle value at least 1.2-fold (0.10 log units) from the limit.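

In this assay compound 4 gives > 230000 nM, a limit. Compound 1 and compound 2 are also limits, so no step among these three compounds can be read. The compounds shown leave open at what amount any of them would show an effect, and whether the group on the aromatic nitrogen alters it.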